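Swapping Propyl for Difluoromethyl on a Slowly Cleared Compound

A few compounds are considered here, and "the series" means these few. Any claim that something is new, unique, unknown or untested is made for them only; others in the source may bear on it.

So far, three compounds have been measured in an ADME assay on the whole organism (Mus musculus, strain CD-1) for pharmacokinetics; on this read-out higher numbers stand for fast clearance and lower numbers for slow clearance. In that test, compound 1 (`COc1cc([C@](O)(CCN(C)C)[C@@H](c2cc3cc(Br)ccc3nc2OC)c2cccc(OC)c2F)cc(OC(C)C)n1`) gives 8.9 mL/min/kg, compound 2 (`CCCOc1cc([C@](O)(CCN(C)C)[C@@H](c2cc3cc(Br)ccc3nc2OC)c2ccnc(OC)c2OC)cc(OC)n1`) gives 6.9 mL/min/kg and compound 3 (`COc1cc([C@](O)(CCN(C)C)[C@@H](c2cc3cc(C#N)ccc3nc2OC)c2cccc(C)c2F)cc(OC(F)F)n1`) gives 13 mL/min/kg. These numbers all lie within the usual scatter of one another, so compound 2 stands level with the other two rather than apart from them.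

Compound 4 (`COc1cc([C@](O)(CCN(C)C)[C@@H](c2cc3cc(Br)ccc3nc2OC)c2ccnc(OC)c2OC)cc(OC(F)F)n1`) has not yet been measured. It keeps compound 2 intact apart from one change, difluoromethyl in place of propyl on an oxygen on an aromatic ring.

Among the measured compounds shown here, no two measured compounds differ in one place only, so the data give no direct measure of this swap. The closest hint is compound 3, which also carries difluoromethyl on an oxygen on an aromatic ring and gives 13 mL/min/kg, but it differs from compound 2 elsewhere too. A small move towards a higher number, not beyond the scatter, is therefore the expectation. The expected change is a 1.4-fold higher number from compound 2 to compound 4 (0.14 log units; within the scatter). For compound 4 the estimated clearance is 9.5 mL/min/kg, with an expected range from 5 mL/min/kg to 18 mL/min/kg.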

Compound 4, clearance: 8.7 mL/min/kg
Compound 4: the middle estimate sits 1.1-fold (0.04 log units) above what was measured; measured number inside the range.
By their numbers in this assay, from the lowest: compounds 2, 4, 1 and 3 (each within the scatter of the next).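

Among the compounds shown here, this is the first direct reading of the swap at this position, an oxygen on an aromatic ring. In this assay, putting difluoromethyl in place of propyl gives a 1.3-fold higher number from compound 2 to compound 4 (0.10 log units; within the scatter), so the two compounds stand level, and this single pair gives no sign that clearance depends on which of these two groups sits here. Both groups have 3 heavy atoms, so the pair shows that carbon can give way to fluorine within a group of that size with the read-out staying within the scatter, though no measurement here offers an explanation for this result.

From the compounds shown here alone, this reading comes from one pair that shares everything else, so whether the same swap gives a similar step when other parts of the molecule differ stays open. Also open, going by these compounds, is how clearance would respond to other groups on this oxygen, such as trifluoromethyl, cyclopropyl or a longer chain like butyl, or to an amine carried at the end of such a chain.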